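Swapping the Carbonyl Substituent of Compound 3

The source may hold more compounds than are shown below. What is called first, only, known or untested is meant among the compounds shown, and "the series" means these compounds.

Compound 1, `Cc1nc(S(C)(=O)=O)ccc1Oc1ncnc(OC2CCN(C(=O)O[C@@H](C)CF)CC2)c1F`, gives 186 nM in a functional assay on isolated protein for inhibition of Glucose-dependent insulinotropic receptor (Homo sapiens), read by HTRF and cAMP accumulation; on this read-out lower numbers stand for an effect already at smaller amounts and higher numbers for an effect only at larger amounts of compound. Compound 2, `CCC1(OC(=O)N2CCC(Oc3ncnc(Oc4ccc(S(C)(=O)=O)nc4C)c3F)CC2)CC1`, gives 22 nM. Compound 3, `Cc1nc(S(C)(=O)=O)ccc1Oc1ncnc(OC2CCN(C(=O)SC3CC3)CC2)c1F`, gives 24.9 nM.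

Compound 3 stands second highest of the three numbers; its nearest neighbour is compound 2, with the gap shown by a 1.1-fold higher number from compound 2 to compound 3 (0.05 log units; within the scatter), while compound 1 lies furthest, as shown by a 7.5-fold lower number from compound 1 to compound 3 (0.87 log units; beyond the scatter).

Compound 4, `Cc1nc(S(C)(=O)=O)ccc1Oc1ncnc(OC2CCN(C(=O)c3ncc(Cl)cn3)CC2)c1F`, differs from compound 3 in one place: a group of 7 heavy atoms (4 carbon, 2 nitrogen, 1 chlorine; one six-membered aromatic ring with 2 hetero atoms) in place of a group of 4 heavy atoms (3 carbon, 1 sulfur; one three-membered non-aromatic ring of carbon only), on a carbonyl carbon. Among the compounds with values here, three measured steps concern the same carbonyl carbon. The steps of an 8.5-fold lower number from compound 1 to compound 2 (0.93 log units; beyond the scatter) and a 7.5-fold lower number from compound 1 to compound 3 (0.87 log units; beyond the scatter) show that exchanging the group on this carbon can move the number modestly, whereas a 1.1-fold higher number from compound 2 to compound 3 (0.05 log units; within the scatter) shows that two ring-bearing groups gave numbers within the scatter of each other. Within the data shown here, none of the measured compounds carries an aromatic group on this carbon, so the step to compound 4 has no direct precedent, and the range must be wide.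

Compound 4 is therefore expected to lie near 40 nM, between 10 nM and 200 nM. The step of a 1.6-fold higher number from compound 3 to compound 4 (0.21 log units; within the scatter) is estimated to stay modest and may fall within the scatter.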

Compound 4, half-maximal effective concentration: 6.12 nM
For compound 4 the middle estimate is 6.5-fold (0.82 log units) above the measured one; the measured number lies below the stated range.
By their numbers in this assay, from the lowest: compound 4; then compounds 2 and 3 (each within the scatter of the next); then compound 1.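

The 5-chloropyrimidin-2-yl group is the only aromatic group shown on this carbonyl carbon, and it gives a lower number than every other group there, with a 4.1-fold lower number from compound 3 to compound 4 (0.61 log units; beyond the scatter) and a 3.6-fold lower number from compound 2 to compound 4 (0.56 log units; beyond the scatter) and, as the only large step at this place, a 30-fold lower number from compound 1 to compound 4 (1.48 log units; beyond the scatter) in this series. Compounds 2 and 3 lie within the scatter of each other, which might have suggested a floor for this place, but compound 4 shows that the number can go lower when a ring replaces the groups joined through oxygen or sulfur, even though the two ring-bearing groups before it differed in size and linking atom without any clear effect. No measurement given here accounts for this drop.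

The compounds shown leave open whether the lower number follows from the chlorine, from the two ring nitrogens, or simply from the ring carbon being bound directly to the carbonyl carbon, as these all enter together in one step. An unsubstituted pyrimidin-2-yl or a phenyl ring at this place would separate these, and a piperidine joined through its nitrogen would show how a non-aromatic ring fares there.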